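The compounds below may be only part of what the source reports. "The series", "measured", "known", "first", "only" and "open" are said of these compounds alone.

In an ADME assay on the whole organism for cytotoxicity, with Artemia salina as the target, with a stated time of 24 h (a higher number here means that more compound is needed for the effect, a lower number that less compound is needed), the measured compounds stand as follows:

compound 1 `Cc1ccc(S(=O)(=O)NC(=O)Nc2ccccc2C(=O)/C=C/c2ccc(N(C)C)cc2)cc1`: 38.1 ug/mL
compound 2 `Cc1ccc(S(=O)(=O)NC(=O)Nc2ccccc2C(=O)/C=C/c2ccccc2O)cc1`: 32.3 ug/mL
compound 3 `Cc1ccc(S(=O)(=O)NC(=O)Nc2ccccc2C(=O)/C=C/c2cccc(F)c2)cc1`: 4.13 ug/mL

Compound 3 gives the lowest of the three numbers, set apart by a 9.2-fold lower number from compound 1 to compound 3 (0.96 log units; beyond the scatter) and by a 7.8-fold lower number from compound 2 to compound 3 (0.89 log units; beyond the scatter), both beyond the scatter; compounds 1 and 2 lie within the scatter of each other, a 1.2-fold lower number from compound 1 to compound 2 (0.07 log units; within the scatter).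

Compound 4 `Cc1ccc(S(=O)(=O)NC(=O)Nc2ccccc2C(=O)/C=C/c2ccc(Cl)cc2Cl)cc1` differs from compound 3 by 2,4-dichlorophenyl in place of 3-fluorophenyl on a double-bonded chain carbon bound to a double-bonded chain carbon. Among the compounds with values here, the measured steps all exchange the aryl group at this same place, but none exchanges one halogenated phenyl for another, so no step bears directly on this change. The two steps into compound 3 show that this position moves this assay by a modest amount. With compound 3 already the lowest number, a step within or near the scatter is expected, a 1.2-fold higher number from compound 3 to compound 4 (0.08 log units; within the scatter). For compound 4 the expected value is 5 ug/mL, range 1.5 ug/mL to 16 ug/mL.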

Compound 4, concentration for half-maximal effect: 8.34 ug/mL
Compound 4: middle estimate off by 1.7-fold (0.22 log units), on the low side; the range from low to high includes it.
By their numbers in this assay, from the lowest: compound 3; then compound 4; then compounds 2 and 1 (each within the scatter of the next).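

In this assay, within the data shown here, the first exchange of one halogenated phenyl for another on a double-bonded chain carbon bound to a double-bonded chain carbon is not silent: a 2.0-fold higher number from compound 3 to compound 4 (0.31 log units; beyond the scatter). The 2,4-dichlorophenyl group still stays clearly apart from the two non-halogenated aryl groups, with a 3.9-fold lower number from compound 2 to compound 4 (0.59 log units; beyond the scatter) and a 4.6-fold lower number from compound 1 to compound 4 (0.66 log units; beyond the scatter), so both halogenated compounds lie at the low end of these four. Nothing measured here accounts for this order.

On these data alone, whether the gap follows the kind, number or placing of the halogens stays open. Also open, as far as these compounds go, is how an unsubstituted phenyl, or a phenyl carrying a nitrile or a carboxylic acid, would read.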